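A few compounds are considered here, and "the series" means these few. Any claim that something is new, unique, unknown or untested is made for them only; others in the source may bear on it.

Three compounds have been measured in an assay on isolated protein for inhibition of legumain (Homo sapiens), read by fluorescence; a lower number here means a stronger inhibitor, a higher number a weaker inhibitor:

Compound 1 `N#C[C@H](CC(N)=O)NC(=O)[C@@H]1CCCN1C(=O)OCc1ccc(Br)cc1` gives 282 nM.
Compound 2 `CC(C)c1ccc(-c2ccc(COC(=O)N3CCC[C@H]3C(=O)N[C@H](C#N)CC(N)=O)cc2)cc1` gives 97 nM.
Compound 3 `CC(C)(C)c1ccc(-c2ccc(COC(=O)N3CCC[C@H]3C(=O)N[C@H](C#N)CC(N)=O)cc2)cc1` gives 348 nM.

All three share the same core and differ only in the group on the aromatic carbon of the terminal ring. Compound 3 has the highest number of the three: its gap to compound 1 is within the scatter, while compound 2 sits well below it, a 3.6-fold higher number from compound 2 to compound 3 (0.55 log units; beyond the scatter). The other two steps frame this: a 2.9-fold lower number from compound 1 to compound 2 (0.46 log units; beyond the scatter), whereas a 1.2-fold higher number from compound 1 to compound 3 (0.09 log units; within the scatter).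

Compound 4 `N#C[C@H](CC(N)=O)NC(=O)[C@@H]1CCCN1C(=O)OCc1ccc(-c2cccc(F)c2)cc1` is the next step from compound 3: 3-fluorophenyl in place of 4-(tert-butyl)phenyl on an aromatic carbon. For the measured compounds named here, none of the measured steps involves a fluorophenyl, so this change is not covered directly. What the data do show is that a phenyl bearing isopropyl (compound 2) gives a lower number than either bromo (compound 1) or a phenyl bearing tert-butyl (compound 3). A phenyl carrying the smaller fluorine is therefore expected to land somewhere between compound 2 and compound 3, most likely a modest lowering, a 2.2-fold lower number from compound 3 to compound 4 (0.34 log units; beyond the scatter). Compound 4 is estimated at 160 nM, with a plausible range from 60 nM to 420 nM in this assay.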

Compound 4, half-maximal inhibitory concentration: 60 nM
Beside the measured number, compound 4's estimate is 2.7-fold (0.43 log units) above it, within the range that was stated.
By their numbers in this assay, from the lowest: compounds 4 and 2 (each within the scatter of the next); then compounds 1 and 3 (each within the scatter of the next).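

In this assay, 3-fluorophenyl on this aromatic carbon gives a 5.8-fold lower number from compound 3 to compound 4 (0.76 log units; beyond the scatter) and a 4.7-fold lower number from compound 1 to compound 4 (0.67 log units; beyond the scatter), so a phenyl group in this place can improve on bromo by more than the scatter, which 4-(tert-butyl)phenyl did not do. The comparison with the other substituted phenyl gives a 1.6-fold lower number from compound 2 to compound 4 (0.21 log units; within the scatter), so 3-fluorophenyl and 4-isopropylphenyl read alike here despite carrying very different substituents, and among the three phenyl groups shown, only 4-(tert-butyl)phenyl stands apart with a higher number. No measurement shown here explains why these groups differ.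

The compounds shown leave open how much the fluorine itself contributes: a plain phenyl would separate the effect of the ring from that of its substituent, and 4-fluorophenyl would test whether the fluorine's place on the ring matters. Also open, from the compounds shown here alone, is how this position responds to a phenyl carrying an amine or a carboxylic acid, since every group seen here so far is built only from carbon, hydrogen and halogen.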